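Trifluoromethyl on the Core: Stability of Compound 3

This account rests on a few compounds, and the source may have more. Where it says the series, first, only, none or still open, it means among the compounds named here.

Measured compounds in an ADME assay on microsomes from liver (Rattus norvegicus) for metabolic stability, with a stated time of 10 min; on this read-out lower numbers stand for a less stable compound and higher numbers for a more stable compound:
compound 1 `Fc1ccccc1-c1ccc2[nH]c(C3=NOC4(CCCCC4)C3)nc2c1` gives 55%
compound 2 `Fc1cccc(C(F)(F)F)c1-c1ccc2[nH]c(C3=NOC4(CCCCC4)C3)nc2c1` gives 37%

Compound 1 gives the highest of the two numbers; the nearest is compound 2, reached by a number 18 percentage points lower from compound 1 to compound 2 (beyond the scatter). Compound 3 `Fc1ccccc1-c1cc(C(F)(F)F)c2[nH]c(C3=NOC4(CCCCC4)C3)nc2c1` differs from compound 1 by trifluoromethyl in place of hydrogen on an aromatic carbon. Among the compounds with values here, the one step that bears on it is the step from compound 1 to compound 2, where the same group entered at a different place and the number fell by a modest amount beyond the scatter. A drop of similar size is therefore expected, as a number 12 percentage points lower from compound 1 to compound 3 (beyond the scatter). Compound 3 is estimated at 43%, within 25% to 62%.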

Compound 3, percent of the compound remaining: 100%
Beside the measured number, compound 3's estimate is 57 percentage points below it; measured number above the stated range.
By their numbers in this assay, from the lowest: compound 2; then compound 1; then compound 3.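

The reading in this assay shows a number 45 percentage points higher from compound 1 to compound 3 (beyond the scatter) when trifluoromethyl enters on this aromatic carbon, ortho to a fused ring, whereas a number 18 percentage points lower from compound 1 to compound 2 (beyond the scatter) came with the same group at a different place. The same change therefore moves the number in opposite directions in these compounds, depending on where it stands. Nothing available accounts for this reversal. From the compounds shown here alone, whether methyl, chlorine or a nitrile on this carbon would go the same way stays open, as does the effect of trifluoromethyl on the other aromatic carbons of the core.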